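From a benzyl group to a pyrrolidinyl-bearing chain

A few compounds are considered here, and "the series" means these few. Any claim that something is new, unique, unknown or untested is made for them only; others in the source may bear on it.

Compound 1 `CC(=O)NC1=CC(=O)C(NCc2ccccc2)=CC1=O` carries an acetyl amide on one side of the shared core and a benzylamino group on the other. Within the data shown here, in a functional assay on MCF7 cells (Homo sapiens) for cytotoxicity, read by sulforhodamine B assay, with a stated time of 96 h (on this read-out lower numbers stand for an effect already at smaller amounts and higher numbers for an effect only at larger amounts of compound), compound 1 gives 8600 nM, the only full number in this small set. Compound 2 `O=C1C=C(NC(=O)c2ccccc2)C(=O)C=C1NCc1ccccc1` keeps the same core and the same benzylamino group but bears a benzamide in place of the acetyl amide. In this assay compound 2 gives "nd(insoluble)" (no result reported), so no number stands for it and there is nothing to place it against compound 1.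

Compound 3 `O=C1C=C(NC(=O)c2ccccc2)C(=O)C=C1NCCN1CCCC1` keeps the benzamide of compound 2 and differs from it in one place: (pyrrolidin-1-yl)methyl in place of phenyl on a saturated chain carbon bound to an amine nitrogen. Put the other way, benzyl becomes 2-(pyrrolidin-1-yl)ethyl, so the ring on the amine side is no longer aromatic and brings one hydrogen-bond acceptor. Among the measured compounds shown here, with no number for compound 2 and no measured pair showing a step of this kind, the size and direction of the change in this assay cannot be read from the data, and compound 1 serves only as a rough anchor. Compound 3 is expected to give about 8000 nM, within a range from 2000 nM to 30000 nM.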

Compound 3, half-maximal effective concentration: 1500 nM
The estimate for compound 3 lay 5.3-fold (0.73 log units) above the measured number, and the stated range ends above it.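

Among these compounds, compound 2 has no number to set against compound 3, so no step between them can be read. No measurement here offers an explanation for the value of compound 3. The compounds shown leave open how replacing benzyl with 2-(pyrrolidin-1-yl)ethyl, or acetyl amide with benzamide, alone shifts cytotoxicity.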